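From 3-hydroxyphenyl to 4-hydroxyphenyl on compound 1

A few compounds are considered here, and "the series" means these few. Any claim that something is new, unique, unknown or untested is made for them only; others in the source may bear on it.

Among the compounds with values here, in a functional assay on CCRF-CEM cells (Homo sapiens) for inhibition, read by MTT assay, with a stated time of 72 h (on this read-out lower numbers stand for stronger inhibition and higher numbers for weaker inhibition), compound 1 (`COc1cc(NC(C)CCCNC(=O)Nc2cccc(O)c2)c2ncccc2c1`) gives 32000 nM, the highest of the three numbers measured so far. Compound 2 (`COc1cc(NC(C)CCCNC(=O)NNC(=O)Nc2cccc(C(F)(F)F)c2)c2ncccc2c1`) gives 6900 nM and compound 3 (`COc1cc(NC(C)CCCNC(=O)NNC(=O)Nc2cc(C(F)(F)F)cc(C(F)(F)F)c2)c2ncccc2c1`) gives 13000 nM, and both numbers lie lower than that of compound 1 by more than the scatter.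

Compound 4 (`COc1cc(NC(C)CCCNC(=O)Nc2ccc(O)cc2)c2ncccc2c1`) has not yet been measured. It carries 4-hydroxyphenyl in place of 3-hydroxyphenyl on an amide-type nitrogen.

Within the data shown here, only one measured step links two compounds that differ in one place, a 1.9-fold higher number from compound 2 to compound 3 (0.28 log units; within the scatter). Among the measured compounds shown here, that step adds trifluoromethyl in place of hydrogen on an aromatic carbon, so it is a different change from the one in compound 4 and offers only weak guidance. For the measured compounds named here, no measured pair exchanges the two hydroxyphenyl groups. With so little to go on, no step beyond the scatter is expected in this assay. The estimated change is a 1.1-fold lower number from compound 1 to compound 4 (0.03 log units; within the scatter). For compound 4 the estimate is 30000 nM, with an expected range from 13000 nM to 70000 nM.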

Compound 4, half-maximal inhibitory concentration: 23000 nM
Estimate against measurement, compound 4: 1.3-fold (0.12 log units) above, and the stated range covers the measured number.
By their numbers in this assay, from the lowest: compounds 2, 3, 4 and 1 (each within the scatter of the next, the first and the last beyond it).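

In this assay, exchanging the two hydroxyphenyl groups on the amide-type nitrogen whose other neighbour is the carbonyl carbon gives a 1.4-fold lower number from compound 1 to compound 4 (0.14 log units; within the scatter). The earlier compounds shown here offered no pair with this exchange, and this first one shows that two groups of the same atoms, joined differently, cannot be told apart at this position in this assay. Nothing among the data shown bears on why the two compounds read alike.

From the compounds shown here alone, whether an aminophenyl or a carboxyphenyl group on the same nitrogen would give a number that stands apart from those of compound 1 and compound 4 remains open. Compound 1 and compound 4 also differ from compound 2 and compound 3 in more than one place, so the compounds shown do not settle what separates those numbers.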